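The source may hold more compounds than are shown below. What is called first, only, known or untested is meant among the compounds shown, and "the series" means these compounds.

Two short amine chains have been tested so far in a functional assay on L1210 cells (Mus musculus) for inhibition, with a stated time of 48 h; a lower number here means a stronger inhibitor, a higher number a weaker inhibitor. Compound 1 `CCNCCCCNCCCN` gives > 100000 nM, which is a limit of the assay and not a number. Compound 2 `CCCNCCCCNCCCN` gives > 100000 nM, again a limit and not a number, so compound 2 has no exact place on the scale. The record so far is the limit of > 100000 nM in this assay, at which 2 of the 2 values shown sit. Among the compounds with values here, the one measured step, methyl in place of hydrogen on a saturated chain carbon, two bonds along the chain from an amine nitrogen, is a step that the two limits leave unreadable from compound 1 to compound 2, so it offers no size to carry forward.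

Compound 3 `CCCNCCCCNCCCCNCCC` comes from a larger change, with (propylamino)methyl in place of amino on a saturated chain carbon, three bonds along the chain from an amine nitrogen. Within the data shown here, with no measured step to size this change, only a tentative expectation is possible: a modest shift towards lower numbers in this assay, with another limit quite possible. Compound 3 is expected at about 60000 nM, with an estimated range from 15000 nM to 150000 nM. This estimate means an expected at least 1.6-fold lower number from compound 2 to compound 3 (0.22 log units; that floor lies within the scatter).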

Compound 3, half-maximal inhibitory concentration: > 100000 nM
Compound 3: only a limit was reported; the forecaster's own chance of this, stated with the estimate: 50%; middle value at least 1.6-fold (0.22 log units) away from the limit.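

In this assay compound 3 gives > 100000 nM as a limit of the assay and not a number. Compound 2 also stands at a limit, so no step size can be read between compound 2 and compound 3. These compounds leave open where any of them truly lies on the scale and whether either change moves it at all: the limit of > 100000 nM in this assay, at which 3 of the 3 values shown sit.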